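Styryl Dichlorophenyl in Place of Chlorophenyl on the Benzyl Arm

The source may report more compounds than this note shows. Statements on the series, on what has been measured and on what is new or still open speak of the compounds shown alone.

Compound 2 `COC(=O)/C=C/c1cccc(N(Cc2ccc(-c3cccc(Cl)c3)cc2)C(=O)C2CCCCC2)c1` gives 94 nM in an assay on isolated protein with Bile acid receptor (Homo sapiens) as the target (on this read-out lower numbers stand for an effect already at smaller amounts and higher numbers for an effect only at larger amounts of compound), and stands second highest of the three values: compound 3 `COC(=O)/C=C/c1cccc(N(Cc2ccc(-c3cccc(Cl)c3)cc2)C(=O)C(C)C)c1` gives 77 nM, while compound 1 `COC(=O)/C=C/c1cccc(N(Cc2ccc(/C=C/c3cc(C(F)(F)F)cc(C(F)(F)F)c3)cc2)C(=O)C2CCCCC2)c1` gives 1470 nM. Compound 4 `COC(=O)/C=C/c1cccc(N(Cc2ccc(/C=C/c3c(Cl)cccc3Cl)cc2)C(=O)C2CCCCC2)c1` differs from compound 2 in one place: 2-(2,6-dichlorophenyl)ethenyl in place of 3-chlorophenyl on an aromatic carbon. Within the data shown here, the only measured step, a 1.2-fold lower number from compound 2 to compound 3 (0.09 log units; within the scatter), concerns the carbonyl side and does not bear on this change. Compound 1, which also carries an ethenyl-linked aryl group, shows a much higher number than compound 2, although the two differ in more than one place, so this is guidance rather than a clean step. On that basis compound 4 is expected to move to a higher number, a 3.2-fold higher number from compound 2 to compound 4 (0.50 log units; beyond the scatter). The value of compound 4 is estimated at 300 nM, between 60 nM and 1500 nM.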

Compound 4, half-maximal effective concentration: 150 nM
Estimate against measurement, compound 4: 2.0-fold (0.30 log units) above, and the stated range covers the measured number.
By their numbers in this assay, from the lowest: compounds 3, 2 and 4 (each within the scatter of the next); then compound 1.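

In this assay, the larger 2-(2,6-dichlorophenyl)ethenyl group on this aromatic carbon replaces 3-chlorophenyl with a 1.6-fold higher number from compound 2 to compound 4 (0.20 log units; within the scatter), so this position accepts the added ethenyl link and second chlorine without a change beyond the scatter. Compound 4 gives 150 nM and compound 1 gives 1470 nM, so an ethenyl link here does not by itself bring the number of compound 1. Nothing measured explains this result. Open, going by these compounds, is how an ethynyl link or a pyridine ring at this position would read in this assay.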